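From a Methoxycarbonyl Group to a Dimethylamino Chain

The source may hold more compounds than are shown below. What is called first, only, known or untested is meant among the compounds shown, and "the series" means these compounds.

In a functional assay on MCF7 cells (Homo sapiens) for antiproliferative activity, read by MTT assay, with a stated time of 72 h (on this read-out higher numbers stand for weaker inhibition and lower numbers for stronger inhibition), compound 3 (`CCn1cc(C(CC)(CC)c2ccc(C#CC(O)(CC)CC)c(C)c2)cc1C(=O)NCC(=O)OC`) gives 26500 nM. Compound 1 (`CCN(CC)CCCNC(=O)c1ccc(C(CC)(CC)c2ccc(C#CC(O)(CC)CC)c(C)c2)n1CC`) gives 17800 nM, and compound 2 (`CCn1c(C(=O)N[C@H](C(=O)O)C(C)C)ccc1C(CC)(CC)c1ccc(C#CC(O)(CC)CC)c(C)c1`) gives 13000 nM. Compound 3 lies within the scatter of compound 1, and the gap between compound 3 and compound 2 lies beyond the scatter. Compound 4 (`CCn1cc(C(CC)(CC)c2ccc(C#CC(O)(CC)CC)c(C)c2)cc1C(=O)NCCCN(C)C`) is still unmeasured and differs from compound 3 as follows: 2-(dimethylamino)ethyl in place of methoxycarbonyl on a saturated chain carbon bound to an amide-type nitrogen. Within the data shown here, one measured step bears on this change, and only indirectly. Exchanging the 3-(diethylamino)propyl group on the amide-type nitrogen gave a 1.4-fold lower number from compound 1 to compound 2 (0.14 log units; within the scatter). No step beyond the scatter is therefore expected in this assay, and the estimated step is a 1.3-fold lower number from compound 3 to compound 4 (0.12 log units; within the scatter). For compound 4 the estimate is 20000 nM, with an expected range from 10000 nM to 38000 nM.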

Compound 4, half-maximal inhibitory concentration: 20200 nM
Beside the measured number, compound 4's estimate is 1.0-fold (0.00 log units) below it; the range from low to high includes it.
By their numbers in this assay, from the lowest: compounds 2, 1, 4 and 3 (each within the scatter of the next, the first and the last beyond it).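

In this assay, putting 2-(dimethylamino)ethyl in place of methoxycarbonyl on a saturated chain carbon bound to an amide-type nitrogen gave a 1.3-fold lower number from compound 3 to compound 4 (0.12 log units; within the scatter), the first step read directly on this core. At this position, then, a chain ending in a dimethylamino group and one ending in methoxycarbonyl cannot be told apart in this assay. Nothing given here accounts for this result. Still open, as far as these compounds go, is whether a free carboxylic acid at this chain end, a longer chain carrying the amine, or a piperidine ring in place of the dimethylamino group would shift the number beyond the scatter.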